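The source may hold more compounds than are shown below. What is called first, only, known or untested is meant among the compounds shown, and "the series" means these compounds.

The set holds three measured compounds and one awaiting measurement, all read in an assay on membranes from brain for binding affinity to Fatty-acid amide hydrolase 1 (Mus musculus), read by fluorescence, with stated times of 1 h and 30 min; a higher number here means a weaker inhibitor, a lower number a stronger inhibitor. Compound 1 `Cc1cnn(C(=O)N2CCCN(Cc3ccc(OCc4ccccc4)cc3)CC2)c1` gives 560 nM in this assay. Compound 2 `O=C(NCc1ccc(OC(c2ccccc2)c2ccccc2)cc1)n1cccn1` returns only a limit of the assay, > 100000 nM, and not a number. Compound 3 `Cc1cnn(C(=O)N(C)CCN(C)C(c2ccc(OCc3ccccc3)cc2)c2ccc(OCc3ccccc3)cc2)c1` likewise returns only a limit, > 1000000 nM, so its standing among the numbers shown is that of a compound without a measured value; it sits at the limit of > 1000000 nM in this assay, at which 1 of the 3 values shown sits, while compound 2 sits at the limit of > 100000 nM in this assay, at which 1 of the 3 values shown sits, and only compound 1 carries a number.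

Compound 4 `CN(CCN(C)C(c1ccc(OCc2ccccc2)cc1)c1ccc(OCc2ccccc2)cc1)C(=O)n1cc(C#N)cn1` differs from compound 3 in one place: cyano in place of methyl on an aromatic carbon, so that 4-methyl-1H-pyrazol-1-yl becomes 4-cyano-1H-pyrazol-1-yl. Within the data shown here, no pair of measured compounds traces this change, and the three values shown share no single difference, so nothing measured here sets the size of the step.

Among the measured compounds shown here, with compound 3 at a limit, the account can expect only that compound 4 moves toward a lower number, by a step of an at least 5.0-fold lower number from compound 3 to compound 4 (0.69 log units; beyond the scatter) if the estimate holds, with a real chance that the assay again reports only a limit. Compound 4 is estimated at 200000 nM, within 2000 nM to 5000000 nM.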

Compound 4, half-maximal inhibitory concentration: > 1000000 nM
Compound 4 ended at the assay's limit; the forecaster's own chance of this, stated with the estimate: 60%; middle value at least 5.0-fold (0.69 log units) away from the limit.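

Compound 4, like compound 3, ends at a limit of this assay and not at a number, so no step from compound 3 to compound 4 can be read: the limit of > 1000000 nM in this assay, at which 2 of the 4 values shown sit.

The compounds shown leave open whether cyano in place of methyl on an aromatic carbon changes the half-maximal inhibitory concentration at all, and by how much.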